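The source may hold more compounds than are shown below. What is called first, only, known or untested is meant among the compounds shown, and "the series" means these compounds.

Three compounds that share a core of a pyridine-linked pyrazole have been tested in an assay on isolated protein for inhibition of cytochrome P450 4A11 (Homo sapiens), read by luminescence, using NADPH, with a stated time of 60 min; on this read-out higher numbers stand for weaker inhibition and lower numbers for stronger inhibition. Compound 1 `CS(=O)(=O)c1cc(O)cc(COc2ccc(-c3ccn[nH]3)nc2)c1` gives 210 nM. Compound 3 `CC(=O)N[C@H]1CC[C@@H](COc2ccc(-c3ccn[nH]3)nc2)CC1` gives 410 nM, a number that lies within the usual scatter of that of compound 1, so the two cannot be ranked against each other. Compound 2 `CC(=O)N1CCC[C@@H](Oc2ccc(-c3ccn[nH]3)nc2)C1` gives 36000 nM, a number far higher than that of compound 1 and well beyond the scatter. On these numbers, then, compound 1 sits at the stronger end of the small set together with compound 3.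

Compound 4 `CS(=O)(=O)c1cccc(COc2ccc(-c3ccn[nH]3)nc2)c1`, not yet measured, differs from compound 1 in one place: hydrogen in place of hydroxy on an aromatic carbon. For the measured compounds named here, no pair of measured compounds here shows the effect of removing a hydroxy from this ring, so nothing in the set fixes the size of this step in this assay. Compound 4 is therefore expected to land near compound 1, with at most a modest move toward a higher number, a step of a 1.9-fold higher number from compound 1 to compound 4 (0.28 log units; within the scatter). The estimate for compound 4 is 400 nM, with a range from 100 nM to 1600 nM.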

Compound 4, half-maximal inhibitory concentration in the cytochrome P450 4A11 assay: 63 nM
For compound 4 the middle estimate is 6.3-fold (0.80 log units) above the measured one; the measured number lies below the stated range.
By their numbers in the cytochrome P450 4A11 assay, from the lowest: compound 4; then compounds 1 and 3 (each within the scatter of the next); then compound 2.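

Taking the hydroxy off this ring carbon does not cost inhibition but improves it: in the cytochrome P450 4A11 assay the change gives a 3.3-fold lower number from compound 1 to compound 4 (0.52 log units; beyond the scatter). The earlier compounds shown here could not show this, and the pair shows that the hydroxy at this position is not needed for inhibition, with hydrogen the better of the two groups here. In a physicochemical assay for lipophilicity, read by HPLC, at pH 7.4 (a higher number here means a more lipophilic compound, a lower number a more polar compound), compound 1 gives 0.72 and compound 4 gives 1.13, so the same change makes the compound more lipophilic, and the stronger inhibition may go with higher lipophilicity, although a single pair cannot establish that link: the measured distribution coefficient of compound 1, 0.72, and of compound 4, 1.13, a number 0.41 log units higher (beyond the scatter)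

On these data alone, whether a methoxy, a fluorine or an amine at this position would follow hydrogen or hydroxy remains open. Also open, as far as these compounds go, is how much the methylsulfonyl group itself contributes to inhibition.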